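The source may hold more compounds than are shown below. What is called first, only, known or untested is meant among the compounds shown, and "the series" means these compounds.

The measured compounds:

compound 1, `CC(C)OC(=O)N1CCC(O[C@H]2CC[C@H](Oc3cnc(S(C)(=O)=O)cn3)CC2)CC1`, 110%
compound 2, `CS(=O)(=O)c1cnc(O[C@H]2CC[C@H](OC3CCN(C(=O)OC4CCOC4)CC3)CC2)cn1`, 105%
compound 3, `CS(=O)(=O)c1cnc(O[C@H]2CC[C@H](OC3CCN(CC4(C(F)(F)F)CC4)CC3)CC2)cn1`, 116%

All three share one core and differ only in the group carried by the amine nitrogen in the ring. Among the compounds with values here, in a functional assay on isolated protein for agonist activity at Glucose-dependent insulinotropic receptor (Homo sapiens), read by HTRF and cAMP accumulation (on this read-out higher numbers stand for larger maximal responses and lower numbers for smaller maximal responses), compound 3 stands highest of the three, although its separation from compound 1 lies within the scatter, as a number 6 percentage points higher from compound 1 to compound 3 (within the scatter) shows; only the step of a number 11 percentage points higher from compound 2 to compound 3 (beyond the scatter) is beyond the scatter, and it is modest. The step of a number 5 percentage points lower from compound 1 to compound 2 (within the scatter) between the two carbamates is within the scatter.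

Compound 4, `CC(F)Cc1nc(CN2CCC(O[C@H]3CC[C@H](Oc4cnc(S(C)(=O)=O)cn4)CC3)CC2)no1`, has not yet been measured. It differs from compound 3 as follows:

5-(2-fluoropropyl)-1,2,4-oxadiazol-3-yl in place of 1-(trifluoromethyl)cyclopropyl on a saturated chain carbon bound to an amine nitrogen in a ring

The measured steps that bear on this change are those that alter the group on the amine nitrogen in the ring, and none of them moved this assay by more than a modest amount. All three compounds reach a maximal response at or above the reference. Compound 4 is therefore expected to remain in the same region, with a step of a number 8 percentage points lower from compound 3 to compound 4 (within the scatter) that is expected to be small. The estimated value for compound 4 in this assay is 108%, with an expected range from 95% to 120%.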

Compound 4, largest response reached (Emax), in percent of the reference or control that the assay uses: 97%
The estimate for compound 4 lay 11 percentage points above the measured number; the measured number falls inside the stated range.
By their numbers in this assay, from the lowest: compounds 4, 2, 1 and 3 (each within the scatter of the next, the first and the last beyond it).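

Within the data shown here, the group on the amine nitrogen in the ring can lower the response in this assay more than the earlier compounds showed, with a number 19 percentage points lower from compound 3 to compound 4 (beyond the scatter) as the largest step so far and a number 13 percentage points lower from compound 1 to compound 4 (beyond the scatter) also passing the scatter, whereas only one earlier step did. The (5-(2-fluoropropyl)-1,2,4-oxadiazol-3-yl)methyl group is nevertheless not separated from the oxolan-3-yl carbamate, as a number 8 percentage points lower from compound 2 to compound 4 (within the scatter) shows, so this maximal response does not set the carbamates as a class apart from the groups attached through a saturated chain carbon. The change brings in a five-membered aromatic ring with 3 hetero atoms and 3 hydrogen-bond acceptors, but nothing available accounts for the fall in response.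

On these data alone, it remains open whether the drop follows the 1,2,4-oxadiazole ring or the 2-fluoropropyl chain on it. A 5-propyl-1,2,4-oxadiazol-3-yl group, or the same ring carrying a 1-(trifluoromethyl)cyclopropyl group, would separate the two, and a simple amide on the ring nitrogen would show how far the response depends on the carbamate oxygen.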